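A Smaller Aryl Amide on a Core Already Without Activity

The source may report more compounds than this note shows. Statements on the series, on what has been measured and on what is new or still open speak of the compounds shown alone.

Compound 1, `O=C(Nc1ccc(Cl)c(-c2nnc3c(Cl)cccn23)c1)c1ccc(F)cc1Cl`, in a functional assay on A549 cells (Homo sapiens) for antiproliferative activity, read by MTT assay, with a stated time of 72 h (on this read-out higher numbers stand for weaker inhibition and lower numbers for stronger inhibition), gives > 100000 nM, which is a limit of the assay rather than a number.
Compound 2, `Cc1cc(Cl)ccc1C(=O)Nc1ccc(Cl)c(-c2nnc3c(Cl)cccn23)c1`, in this assay gives > 100000 nM, again a limit of the assay.

Both measured compounds share a core and differ only in the aryl group on the carbonyl carbon. Because both values sit at the limit, the step that the two limits leave unreadable from compound 1 to compound 2 cannot be read; the only evidence shown is the limit of > 100000 nM in this assay, at which 2 of the 2 values shown sit, where both measured values sit. Compound 2 therefore stands at the limit, with no ranking possible against compound 1.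

Compound 3, `O=C(Nc1ccc(Cl)c(-c2nnc3c(Cl)cccn23)c1)c1ccccc1`, is related to compound 2 by phenyl in place of 4-chloro-2-methylphenyl on a carbonyl carbon. Going by the values given here, no measured step bears on this change, since the single step between the measured compounds is unreadable. The expectation thus rests only on the fact that both measured compounds are at the limit, and no measured step beyond the scatter is known in either direction.

Compound 3 is estimated at 100000 nM, with a range from 30000 nM to 300000 nM. The estimate means an expected step of a number no higher from compound 2 to compound 3 (the limit leaves the size open), not beyond the scatter, and most likely another limit.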

Compound 3, half-maximal inhibitory concentration: 76900 nM
Estimate against measurement, compound 3: 1.3-fold (0.11 log units) above, within the range that was stated.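

In this assay, going by these compounds alone, compound 3 gives 76900 nM, the only value among the three compounds that is a number and not a limit, so this position on a carbonyl carbon can give a readable result on the shared core. Phenyl in place of 4-chloro-2-methylphenyl gives an at least 1.3-fold lower number from compound 2 to compound 3 (0.11 log units; that floor lies within the scatter), and phenyl in place of 2-chloro-4-fluorophenyl gives an at least 1.3-fold lower number from compound 1 to compound 3 (0.11 log units; that floor lies within the scatter). Each of these steps has only a floor, that floor does not go beyond the scatter, and the step between compound 1 and compound 2 still cannot be read, so the other two compounds can be placed only at a limit: the limit of > 100000 nM in this assay, at which 2 of the 3 values shown sit.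

The compounds shown leave open how large either step really is, and so whether the substituted aryl groups differ from phenyl by more than the scatter. They also leave open how the shared core would read in this assay with an amine or a carboxylic acid on the phenyl, or with a longer chain in place of the phenyl on the carbonyl carbon.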